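The compounds below may be only part of what the source reports. "The series", "measured", "known", "first", "only" and "open" are said of these compounds alone.

The series shares one core and varies the aryl on the carbonyl carbon. Within the data shown here, compound 2 `CCc1ccc(C(=O)Nc2ccc(Nc3ncnc4cc(OC)c(OC)cc34)cc2)cc1` is the only member with a number rather than a limit: in a functional assay on HepG2 cells (Homo sapiens) for inhibition, read by MTT assay (a lower number here means a stronger inhibitor, a higher number a weaker inhibitor), compound 2 gives 72000 nM. Compound 1 `COc1cc2ncnc(Nc3ccc(NC(=O)c4ccccc4OC)cc3)c2cc1OC` differs from compound 2 only in that aryl. In this assay compound 1 reaches a limit of the assay, > 100000 nM. Among the measured compounds shown here, the step of an at least 1.3-fold lower number from compound 1 to compound 2 (0.14 log units; that floor lies within the scatter) is the single measured step, and it lies within the scatter, so exchanging the aryl on the carbonyl carbon has not yet moved the number beyond it. Compound 3 `COc1cc2ncnc(Nc3ccc(NC(=O)c4cc(F)ccc4Br)cc3)c2cc1OC` carries another exchange at the same place: 2-bromo-5-fluorophenyl in place of 4-ethylphenyl on a carbonyl carbon. For the measured compounds named here, the one measured step bears on it but gives no direction, and given the limit of > 100000 nM in this assay, at which 1 of the 2 values shown sits, a limit instead of a number remains possible. For compound 3 a step of a 1.1-fold higher number from compound 2 to compound 3 (0.05 log units; within the scatter) is expected, meaning none beyond the scatter. The estimate for compound 3 in this assay is 80000 nM, between 25000 nM and 250000 nM.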

Compound 3, half-maximal inhibitory concentration: 22000 nM
The estimate for compound 3 lay 3.6-fold (0.56 log units) above the measured number; the whole stated range lies above it.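

Among these compounds, this position does respond in this assay: 2-bromo-5-fluorophenyl in place of 4-ethylphenyl on the carbonyl carbon gives a 3.3-fold lower number from compound 2 to compound 3 (0.51 log units; beyond the scatter), the first step at this place beyond the scatter. Against 2-methoxyphenyl, the same group gives an at least 4.5-fold lower number from compound 1 to compound 3 (0.65 log units; beyond the scatter), so compound 3 is the strongest of the three, with its steps to both others beyond the scatter. Compound 1 stands at a limit of the assay, so this second step is a floor and not a full size: the limit of > 100000 nM in this assay, at which 1 of the 3 values shown sits.

The compounds shown leave open whether the step belongs to the bromine, to the fluorine or to the two together. Also open, from the compounds shown here alone, is how an aryl carrying an amine or a carboxylic acid would compare with the 2-bromo-5-fluorophenyl of compound 3.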